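The source may hold more compounds than are shown below. What is called first, only, known or untested is meant among the compounds shown, and "the series" means these compounds.

Compounds measured so far:
compound 1, `CCCS(=O)(=O)Nc1ccc(F)c(C(=O)c2n[nH]c3ncc(-c4ccccc4F)cc23)c1F`, 2%
compound 2, `CCCS(=O)(=O)Nc1ccc(F)c(C(=O)c2n[nH]c3ncc(-c4ccc(C)cc4)cc23)c1F`, 5.4%
compound 3, `CCCS(=O)(=O)Nc1ccc(F)c(C(=O)c2n[nH]c3ncc(-c4ccc([N+](=O)[O-])cc4)cc23)c1F`, 4.2%

All three were tested in an assay for binding affinity to dual specificity mitogen-activated protein kinase kinase 4 (Homo sapiens), read by KINOMEscan, tested at 100 nM; on this read-out higher numbers stand for a weaker effect at the one concentration tested and lower numbers for a stronger effect. Compound 3 stands second highest of the three numbers: its nearest neighbour is compound 2, with a number 1.2 percentage points lower from compound 2 to compound 3 (within the scatter), and the furthest is compound 1, with a number 2.2 percentage points higher from compound 1 to compound 3 (within the scatter). The third comparison, a number 3.4 percentage points higher from compound 1 to compound 2 (within the scatter), is likewise within the scatter, so the three compounds cannot be told apart on this read-out.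

Compound 4, `CCCS(=O)(=O)Nc1ccc(F)c(C(=O)c2n[nH]c3ncc(-c4ccc(NS(C)(=O)=O)cc4)cc23)c1F`, is the next compound to be measured. It differs from compound 3 in one place: methanesulfonamido in place of nitro on an aromatic carbon. The measured steps that bear on this change are the two that swap the group on the same aromatic carbon, a number 2.2 percentage points higher from compound 1 to compound 3 (within the scatter) and a number 1.2 percentage points lower from compound 2 to compound 3 (within the scatter), which replace a 2-fluorophenyl or a 4-methylphenyl by a 4-nitrophenyl; neither moved this assay beyond the scatter. Compound 4 is therefore expected to sit close to compound 3, and the expected step is a number 0.8 percentage points higher from compound 3 to compound 4 (within the scatter), none beyond the scatter. Compound 4 is estimated to give 5% in this assay. The expected range for compound 4 runs from 1% to 15%.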

Compound 4, a percentage reported as activity, at one concentration (the size of the read-out at that concentration, not a potency): 0.85%
Compound 4: middle estimate off by 4.2 percentage points, on the high side; measured number below the stated range.
By their numbers in this assay, from the lowest: compounds 4, 1, 3 and 2 (each within the scatter of the next).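

In this assay, the 4-(methanesulfonamido)phenyl group of compound 4 shows that this position accepts a substituent with more heavy atoms than nitro and with a hydrogen-bond donor, which nitro lacks, with a number 3.4 percentage points lower from compound 3 to compound 4 (within the scatter). The comparisons with the two other groups read the same way, with a number 4.6 percentage points lower from compound 2 to compound 4 (within the scatter) and a number 1.2 percentage points lower from compound 1 to compound 4 (within the scatter), so the four compounds cannot be told apart on this read-out and no substituent on this ring has yet moved it beyond the scatter. Nothing measured here explains why such different groups give such similar numbers at this position.

The compounds shown leave open whether any group at this position would move the number beyond the scatter, for example an amine, a carboxylic acid or a longer chain on the sulfonamide in place of the methyl. They also leave open whether these four compounds differ in potency, since a single concentration gives the size of the read-out and not a potency, and all four numbers lie within the scatter of one another.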